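Swapping a butyl ether for a fluorobenzyl ether

This account rests on a few compounds, and the source may have more. Where it says the series, first, only, none or still open, it means among the compounds named here.

Measured so far in an ADME assay on KB cells (Homo sapiens) for cytotoxicity; on this read-out lower numbers stand for an effect already at smaller amounts and higher numbers for an effect only at larger amounts of compound:
compound 1 `CCOC(=O)N1[C@@H]2C=C[C@@](OC)(C(=O)c3c2cc(OC)c(OC)c3OCc2ccc(F)cc2)N1C(=O)OCC`: 51.8 ug/mL
compound 2 `COC(=O)N1[C@@H]2C=C[C@@](OC)(C(=O)c3c2cc(OC)c(OC)c3OCc2ccccc2)N1C(=O)OC`: a limit of the assay, > 300 ug/mL
compound 3 `CCCCOc1c(OC)c(OC)cc2c1C(=O)[C@]1(OC)C=C[C@H]2N(C(=O)OCC(C)C)N1C(=O)OCC(C)C`: 22.1 ug/mL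

Compound 3 has the lowest number of the two numbers available; compound 1 sits higher by a step beyond the usual scatter, and the value of compound 2 is only a limit (the limit of > 300 ug/mL in this assay, at which 1 of the 3 values shown sits). Compound 4 `COc1cc2c(c(OCc3ccccc3F)c1OC)C(=O)[C@]1(OC)C=C[C@H]2N(C(=O)OCC(C)C)N1C(=O)OCC(C)C` differs from compound 3 by 2-fluorophenyl in place of propyl on a saturated chain carbon bound to an oxygen on an aromatic ring. Compound 1 and compound 2, which also carry an aromatic ring at this place, give higher numbers than compound 3, so a moderate rise is expected from compound 3 to compound 4 in this assay, a 2.0-fold higher number from compound 3 to compound 4 (0.31 log units; beyond the scatter). Compound 4 is therefore estimated at 45 ug/mL, within 15 ug/mL to 140 ug/mL.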

Compound 4, concentration for half-maximal effect: 109 ug/mL
Compound 4: the middle estimate sits 2.4-fold (0.38 log units) below what was measured; low and high end bracket the measured number.
By their numbers in this assay, from the lowest: compound 3; then compound 1; then compound 4. At a limit, above all of these: compound 2.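

Among these compounds, this is the first pair that differs in one place only, so the swap of butyl for 2-fluorobenzyl on the oxygen can now be read directly in this assay: a 4.9-fold higher number from compound 3 to compound 4 (0.69 log units; beyond the scatter). Compound 1 and compound 2 also carry an aromatic ring at this place, but they differ from compound 3 elsewhere too. With the rest of the molecule held the same, this place clearly responds to the change.

An amine, a longer chain or a plain benzyl at this place could show how far this trend extends. Nothing in the data given explains the rise.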